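Cyclohexyl for cyclopentyl on an amide-type nitrogen

The source may report more compounds than this note shows. Statements on the series, on what has been measured and on what is new or still open speak of the compounds shown alone.

In a functional assay on HepG2 cells (Homo sapiens) for antiproliferative activity, read by MTT assay, with a stated time of 72 h (a higher number here means a weaker inhibitor, a lower number a stronger inhibitor), the measured compounds gave these values:
Compound 1 `Cc1noc(C)c1-c1nn(Cc2ccc(C(=O)N3CCCCC3)cc2)c(=O)c2ccccc12`: 97300 nM
Compound 2 `Cc1noc(C)c1-c1nn(Cc2ccc(C(=O)NC3CCCC3)cc2)c(=O)c2ccccc12`: > 100000 nM (a limit)

Compound 2 gives > 100000 nM as a limit of the assay and no number. It stands at the limit of > 100000 nM in this assay, at which 1 of the 2 values shown sits, on the values shown.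

Compound 3 `Cc1noc(C)c1-c1nn(Cc2ccc(C(=O)NC3CCCCC3)cc2)c(=O)c2ccccc12` differs from compound 2 by cyclohexyl in place of cyclopentyl on an amide-type nitrogen and thus has cyclohexyl in place of cyclopentyl on an amide-type nitrogen. Among the measured compounds shown here, only one measured step bears on this change. That step is an at least 1.0-fold higher number from compound 1 to compound 2 (0.01 log units; that floor lies within the scatter) and it sets no size for a change beyond the scatter. No step beyond the scatter is therefore expected in this assay in either direction. For the measured compounds named here, the expectation rests on compound 1 with 97300 nM as the only number available. The expected step is a number no higher from compound 2 to compound 3 (the limit leaves the size open) in this reading. Compound 3 is estimated at 100000 nM with an expected range from 50000 nM to 200000 nM in this account.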

Compound 3, half-maximal inhibitory concentration: > 100000 nM
Compound 3: only a limit was reported; the forecaster's own chance of this, stated with the estimate: 60%; the middle value sits exactly at the limit.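

In this assay compound 3 gives > 100000 nM, which is a limit of the assay and not a number. Cyclohexylamino in place of piperidin-1-yl on the carbonyl carbon gives an at least 1.0-fold higher number from compound 1 to compound 3 (0.01 log units; that floor lies within the scatter), so this comparison, like the earlier one with cyclopentylamino, sets no size for a change. Going from a five-membered to a six-membered ring on the amide-type nitrogen adds a second compound at the ceiling, and the step between the two rings cannot be read, so the position now has two compounds without a number: the limit of > 100000 nM in this assay, at which 2 of the 3 values shown sit.

On these data alone, whether the ring size on this nitrogen matters at all stays open, as neither ring gives a number. Also open, as far as these compounds go, is how a longer chain, or a cyclohexyl ring carrying an amine or a carboxylic acid, would read on the amide-type nitrogen in this assay.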